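The source may hold more compounds than are shown below. What is called first, only, known or untested is meant among the compounds shown, and "the series" means these compounds.

Within the data shown here, compound 1 `Cc1cc(OCCCCCCC[N+]2(C)CCCC2)cc(-n2cc(C(=O)Nc3cc(F)cc(F)c3)c(=O)c3ccc(N(C)C)nc32)c1` is the only member of the series with a number to its name: in an assay on LX2 cells for inhibition of COL1A1 promoter (Homo sapiens), read by a luciferase reporter, with a stated time of 24 h, tested at 20 uM (on this read-out lower numbers stand for a weaker effect and higher numbers for a stronger effect at the one concentration tested), compound 1 gives 4.32%, a weak effect at the one concentration tested. Compound 2 `CC[N+]1(CCCCCCCOc2ccc(-n3cc(C(=O)Nc4cc(F)cc(F)c4)c(=O)c4ccc(N(C)C)nc43)c(C)c2)CCCCC1` in this assay is reported as "not active" (no number reported), with no number behind it. Compound 3 `Cc1cc(OCCCCCCC[N+](C)(C)C2CCCCC2)cc(-n2cc(C(=O)Nc3cc(F)cc(F)c3)c(=O)c3ccc(N(C)C)nc32)c1` differs from compound 1 by a group of 9 heavy atoms (8 carbon, 1 nitrogen; one six-membered non-aromatic ring of carbon only) in place of a group of 6 heavy atoms (5 carbon, 1 nitrogen; one five-membered non-aromatic ring with 1 hetero atom), on a saturated chain carbon, seven bonds along the chain from an oxygen on an aromatic ring. Among the measured compounds shown here, no measured pair shows a change of this kind, so nothing fixes its size. The step of a number 0.3 percentage points lower from compound 1 to compound 3 (within the scatter) is expected to stay within the usual scatter, with no clear direction. Compound 3 is estimated at 4%, in the range -8% to 16%.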

Compound 3, a percentage reported as inhibition, at one concentration (the size of the read-out at that concentration, not a potency): 52.5%
Compound 3: middle estimate off by 48.5 percentage points, on the low side; measured number outside the range, above it.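

At the place on a saturated chain carbon, seven bonds along the chain from an oxygen on an aromatic ring, the read-out in this assay responds strongly to the group exchanged (a number 48.2 percentage points higher from compound 1 to compound 3 (beyond the scatter)). Both groups carry net charge +1 and 0 hydrogen-bond donors or acceptors, so these counts stay the same across the step. No measured evidence on hand explains the step.
One pair cannot separate ring type from group size. Going by these compounds, a trimethylammonium end or a cyclopentyl ring on the same nitrogen would bear on that, and a longer chain remains open.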